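A Methoxy Substituent Explored on an Unmeasured Analogue

The source may hold more compounds than are shown below. What is called first, only, known or untested is meant among the compounds shown, and "the series" means these compounds.

Compound 1 `COc1cc(/C=C/C(=O)c2cccc(-n3cc(-c4ccccc4)[nH]c3=O)c2)ccc1O` has the lower of the two numbers recorded so far in a functional assay on OVCAR-3 cells (Homo sapiens) for inhibition (a higher number here means a weaker inhibitor of growth, a lower number a stronger inhibitor of growth), where compound 1 gives 2290 nM. Within the data shown here, its only measured neighbour is compound 2 `O=C(/C=C/c1cccc(O)c1)c1cccc(-n2cc(-c3ccccc3)[nH]c2=O)c1`, which in this assay gives 3080 nM; the step of a 1.3-fold higher number from compound 1 to compound 2 (0.13 log units; within the scatter) alters the group on the double-bonded chain carbon and tells nothing about the other end of the molecule.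

Compound 3 `COc1ccc(-c2cn(-c3cccc(C(=O)/C=C/c4ccc(O)c(OC)c4)c3)c(=O)[nH]2)cc1` differs from compound 1 at that other end: methoxy in place of hydrogen on an aromatic carbon, on an aromatic carbon of a six-membered aromatic ring of carbon only, so that phenyl becomes 4-methoxyphenyl. Among the measured compounds shown here, no measured pair shows this change, and the one step known lies within the scatter. The data therefore give no ground for a shift beyond the scatter in this assay, in either direction.

Compound 3 is accordingly expected to give 2300 nM in this assay, within a range of 900 nM to 6000 nM. This estimate amounts to the step of a 1.0-fold higher number from compound 1 to compound 3 (0.00 log units; within the scatter), which is expected to be nothing more than ordinary variation.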

Compound 3, concentration for 50% growth inhibition: 2700 nM
The estimate for compound 3 lay 1.2-fold (0.07 log units) below the measured number, within the range that was stated.
By their numbers in this assay, from the lowest: compounds 1, 3 and 2 (each within the scatter of the next).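

Among these compounds, until now, the only measured step concerned the group on the double-bonded chain carbon, so nothing was known about the phenyl at the other end of the molecule. In this assay, the step of a 1.2-fold higher number from compound 1 to compound 3 (0.07 log units; within the scatter) supplies the first reading there: with methoxy para to a large group, turning phenyl into 4-methoxyphenyl, the number stays within the scatter. This position therefore carries a group of 2 heavy atoms, with 1 hydrogen-bond acceptor, and no change in growth inhibition can be read from it, although no information is available that would explain this result.

This single substitution says nothing about how an amine, a carboxylic acid, or a longer chain such as butoxy would behave at the same place on the ring, nor about methoxy placed elsewhere on it. On these data alone, it also remains open whether 4-methoxyphenyl would give a similar result when paired with the 3-hydroxyphenyl of compound 2, since the change has been read only against the 4-hydroxy-3-methoxyphenyl of compound 1.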